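Chloro in place of methyl: compound 3 to compound 4

The source may hold more compounds than are shown below. What is called first, only, known or untested is meant among the compounds shown, and "the series" means these compounds.

Of the compounds shown here, three have been read in a functional assay on OVCAR-3 cells (Homo sapiens) for antiproliferative activity, read by MTT assay, with a stated time of 24 h; a lower number here means a stronger inhibitor, a higher number a weaker inhibitor. Compound 1 `O=C(NNc1ccccc1F)c1ccc(NS(=O)(=O)c2cnc(O)nc2O)cc1` reports only a limit (> 20000 nM). Among the compounds with values here, compound 2 `O=C(NNc1ccccc1F)c1cccc(NS(=O)(=O)c2cnc(O)nc2O)c1` gives the one numeric value (17000 nM). Compound 3 `Cc1ccccc1NNC(=O)c1ccccc1NS(=O)(=O)c1cnc(O)nc1O` also reports only a limit (> 20000 nM). Compound 3 therefore sits on the limit of > 20000 nM in this assay, at which 2 of the 3 values shown sit, and has no number of its own.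

Compound 4 `O=C(NNc1ccccc1Cl)c1ccccc1NS(=O)(=O)c1cnc(O)nc1O` differs from compound 3 at one place (chloro in place of methyl on an aromatic carbon): chloro in place of methyl on an aromatic carbon, ortho to a large group. Within the data shown here, no measured pair differs in one place, so this change has no direct precedent. In this assay no step beyond the scatter is expected, and no direction is favoured. The expectation rests on compound 3, whose reading (> 20000 nM) is a limit. The expected step is small (a number no higher from compound 3 to compound 4 (the limit leaves the size open)). Compound 4 is estimated at 20000 nM in this assay, with an expected range of 9000 nM to 45000 nM and a real chance of a limit instead of a number.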

Compound 4, half-maximal inhibitory concentration: 14100 nM
Estimate against measurement, compound 4: 1.4-fold (0.15 log units) above; measured number inside the range.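

Within the data shown here, the change of methyl to chloro on an aromatic carbon, ortho to a large group, is the only one-place comparison so far, and in this assay it gives an at least 1.4-fold lower number from compound 3 to compound 4 (0.15 log units; that floor lies within the scatter). From the compounds shown here alone, compound 3 reports only a limit, > 20000 nM, so the true size of this step remains unknown. This position therefore tolerates a change that brings a numeric reading into the series, but the reading still has to be set against a limit that is common in this set: the limit of > 20000 nM in this assay, at which 2 of the 4 values shown sit.

The compounds shown leave open how a methoxy group, an amine or a carboxylic acid on this aromatic carbon would read. Going by these compounds, with a single pair, it also remains open whether chloro in place of methyl would give a similar step elsewhere.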